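The source may report more compounds than this note shows. Statements on the series, on what has been measured and on what is new or still open speak of the compounds shown alone.

In an assay on blood for inhibition of C-X-C chemokine receptor type 3 (Homo sapiens), with a stated time of 30 min (a higher number here means a weaker inhibitor, a lower number a stronger inhibitor), the measured compounds stand as follows:
compound 1 `C[C@@H]1CN(c2sc(C3COC3)nc2-c2nc3ccccc3[nH]2)CCN1C(=O)Cn1cnc2cccnc21` gives 1150 nM;
compound 2 `CCOc1ncc(-c2nc(C(F)(F)F)sc2N2CCN(C(=O)Cn3cnc4cccnc43)[C@H](C)C2)cn1` gives 48 nM;
compound 3 `CCOc1ncc(-c2nc(C(F)(F)F)sc2N2CCN(C(=O)Cn3cnc4ccccc43)[C@H](C)C2)cn1` gives 192 nM.

Compound 3 holds the second highest of these three numbers. Its nearest neighbour is compound 2, separated by the step of a 4.0-fold higher number from compound 2 to compound 3 (0.60 log units; beyond the scatter), and its furthest is compound 1, whose number is higher than that of compound 3. Compound 4 `CCOc1ncc(-c2nc(C(F)(F)F)sc2N2CCN(C(=O)Cn3ccc4cnccc43)[C@H](C)C2)cn1` is built from the same atoms as compound 3, joined differently: a group of 9 heavy atoms (7 carbon, 2 nitrogen; one five-membered aromatic ring with 1 hetero atom, one six-membered aromatic ring with 1 hetero atom) in place of a group of 9 heavy atoms (7 carbon, 2 nitrogen; one five-membered aromatic ring with 2 hetero atoms, one six-membered aromatic ring of carbon only), on a saturated chain carbon bound to a carbonyl carbon. Among the measured compounds shown here, only one measured step bears on this position, a 4.0-fold higher number from compound 2 to compound 3 (0.60 log units; beyond the scatter), which shows that exchanging the arrangement of ring nitrogens in this group shifts the number by a modest amount; no measured pair shows the group that enters in compound 4. Since the step of a 4.0-fold higher number from compound 2 to compound 3 (0.60 log units; beyond the scatter) was modest, a change of similar size in either direction, or none beyond the scatter, is expected here. Compound 4 is therefore estimated at about 150 nM, within 50 nM to 450 nM. This estimate corresponds to an expected step of a 1.3-fold lower number from compound 3 to compound 4 (0.11 log units; within the scatter).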

Compound 4, half-maximal inhibitory concentration: 25 nM
Estimate against measurement, compound 4: 6.0-fold (0.78 log units) above, outside the stated range (below it).
By their numbers in this assay, from the lowest: compounds 4 and 2 (each within the scatter of the next); then compound 3; then compound 1.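

In this assay, the group on the saturated chain carbon bound to a carbonyl carbon matters even when its atoms stay the same: replacing 1H-benzimidazol-1-yl gives a 7.7-fold lower number from compound 3 to compound 4 (0.89 log units; beyond the scatter) with no change in the counted atoms, donors, acceptors or charge. The other comparison, a 1.9-fold lower number from compound 2 to compound 4 (0.28 log units; within the scatter), shows that the groups of compound 2 and compound 4 are not separated in this assay, although both stand apart from 1H-benzimidazol-1-yl in compound 3. Nothing available explains why the joining of these atoms makes this difference.

The compounds shown leave open whether an amine or a methoxy group on the six-membered aromatic ring of the entering group would be tolerated. They also leave open whether that group would give a similar number on the core of compound 1.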